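The source may report more compounds than this note shows. Statements on the series, on what has been measured and on what is new or still open speak of the compounds shown alone.

Compound 1 `CC(C)(C)c1cc(NC(=O)c2c(Cl)cc(N)cc2Cl)ccc1O` gives 5200 nM in an assay on isolated protein for antagonist activity at Bile acid receptor (Homo sapiens), read by HTRF, with a stated time of 30 min; on this read-out lower numbers stand for stronger inhibition and higher numbers for weaker inhibition. Compound 2 `CC(C)(C)c1cc(NC(=O)c2c(Cl)cc(NC3CCCC3)cc2Cl)ccc1O` gives 5000 nM. Compound 3 `CC(C)(C)c1cc(NC(=O)c2c(Cl)cc(NC3CCCCC3)cc2Cl)ccc1O` gives 2500 nM.

Compound 3 holds the lowest of the three numbers: the step of a 2.0-fold lower number from compound 2 to compound 3 (0.30 log units; within the scatter) stays within the scatter, while the step of a 2.1-fold lower number from compound 1 to compound 3 (0.32 log units; beyond the scatter) lies just beyond it and is modest. Compound 4 `CN(c1cc(Cl)c(C(=O)Nc2ccc(O)c(C(C)(C)C)c2)c(Cl)c1)C1CCCCC1` is compound 3 with methyl in place of hydrogen on a nitrogen on an aromatic ring. Within the data shown here, no measured pair shows exactly this change; the steps of a 1.0-fold lower number from compound 1 to compound 2 (0.02 log units; within the scatter) and a 2.1-fold lower number from compound 1 to compound 3 (0.32 log units; beyond the scatter) only show that substituents on this nitrogen shift this assay little. The expected step of no change at the digits printed from compound 3 to compound 4 (within the scatter) is therefore none beyond the scatter. Compound 4 is estimated at 2500 nM, between 1000 nM and 6500 nM.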

Compound 4, half-maximal inhibitory concentration: > 100000 nM
Compound 4 was reported as a limit (the forecaster's own chance of this, stated with the estimate: 5%); middle value at least 40-fold (1.60 log units) away from the limit.
By their numbers in this assay, from the lowest: compounds 3, 2 and 1 (each within the scatter of the next, the first and the last beyond it). At a limit, above all of these: compound 4.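

In this assay compound 4 is reported only as a limit: the limit of > 100000 nM in this assay, at which 1 of the 4 values shown sits. Among these compounds, compounds 1, 2 and 3 all keep a hydrogen on this nitrogen, and the earlier steps showed only that the other substituent there shifts the number little. Removing that last hydrogen is a different matter: methyl in its place gives an at least 40-fold higher number from compound 3 to compound 4 (1.60 log units; beyond the scatter), and the other two compounds show an at least 20-fold higher number from compound 2 to compound 4 (1.30 log units; beyond the scatter) and an at least 19-fold higher number from compound 1 to compound 4 (1.28 log units; beyond the scatter).

Going by these compounds, it remains open whether methyl has the same effect with cyclopentyl or without a ring on this nitrogen. On these data alone, it is also open whether ethyl or acetyl there would give a measurable number.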